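Ethyl to isopropyl in a series at its limit

The source may hold more compounds than are shown below. What is called first, only, known or untested is meant among the compounds shown, and "the series" means these compounds.

Measured in a functional assay on DU-145 cells (Homo sapiens) for inhibition, read by MTT assay, with a stated time of 48 h (a lower number here means a stronger inhibitor, a higher number a weaker inhibitor), each value a limit:
compound 1 `CCn1c(/C=C2\SC(=O)N(CC(=O)Nc3cc(C(C)(C)C)on3)C2=O)nc2ccccc21`: > 50000 nM
compound 2 `CCn1c(/C=C2\SC(=O)N(CC(=O)N3CC(C)OC(C)C3)C2=O)nc2ccccc21`: > 50000 nM
compound 3 `CCn1c(/C=C2\SC(=O)N(CC(=O)N3CCOCC3)C2=O)nc2ccccc21`: > 50000 nM

Compound 2 stands at > 50000 nM, which is a limit and not a number. The whole set shares this position: the limit of > 50000 nM in this assay, at which 3 of the 3 values shown sit. Compound 4 `CC1CN(C(=O)CN2C(=O)S/C(=C\c3nc4ccccc4n3C(C)C)C2=O)CC(C)O1` differs from compound 2 by methyl in place of hydrogen on a saturated chain carbon bound to an aromatic nitrogen and a saturated chain carbon, the same difference reading ethyl to isopropyl. The measured steps are a step that the two limits leave unreadable from compound 1 to compound 2, a step that the two limits leave unreadable from compound 1 to compound 3 and a step that the two limits leave unreadable from compound 2 to compound 3. All three are changes on a carbonyl carbon, none touches the ethyl, and none has a readable size to carry over. In this assay no change beyond the scatter is expected, in either direction: a step that the limit leaves unreadable from compound 2 to compound 4. Compound 4 is estimated at 60000 nM, with an expected range of 30000 nM to 120000 nM, and most likely it will report only a limit.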

Compound 4, half-maximal inhibitory concentration: > 50000 nM
Compound 4 gave a limit, no number (the forecaster's own chance of this, stated with the estimate: 85%); the middle value does not contradict the limit.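

Compound 2 and compound 4 both report only a limit, so the ethyl to isopropyl change yields no readable step. The compounds shown leave open whether any change to this series would give a number rather than a limit: the limit of > 50000 nM in this assay, at which 4 of the 4 values shown sit.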